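Thiazolyl sulfonamide step across two chlorocoumarin imine cores

The compounds below may be only part of what the source reports. "The series", "measured", "known", "first", "only" and "open" are said of these compounds alone.

Measured compounds:
compound 1 `NS(=O)(=O)c1ccc(/N=C/c2c(Cl)c3ccccc3oc2=O)cc1`, 300 nM
compound 2 `O=c1oc2ccccc2c(Cl)c1/C=N/c1ccc(S(=O)(=O)Nc2nccs2)cc1`, 300 nM
compound 3 `CC(C)(C)c1cc(C(C)(C)C)c2oc(=O)c(/C=N/c3ccc(S(N)(=O)=O)cc3)c(Cl)c2c1`, 240 nM

In a functional assay on B16-F10 cells (Mus musculus) for cytotoxicity, read by CCK-8 assay, with a stated time of 48 h (on this read-out higher numbers stand for weaker inhibition and lower numbers for stronger inhibition), compound 1 gives 300 nM and compound 2 gives 300 nM. The change from compound 1 to compound 2 is 1,3-thiazol-2-yl in place of hydrogen on a sulfonamide nitrogen, and its step is no change at the digits printed from compound 1 to compound 2 (within the scatter). Compound 3 gives 240 nM in this assay; the difference between its core and the core of compound 1 is not broken down here, and the two values lie within the scatter of each other.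

Compound 4 `CC(C)(C)c1cc(C(C)(C)C)c2oc(=O)c(/C=N/c3ccc(S(=O)(=O)Nc4nccs4)cc3)c(Cl)c2c1` is not yet measured. It differs from compound 3 by 1,3-thiazol-2-yl in place of hydrogen on a sulfonamide nitrogen, the same change as from compound 1 to compound 2, made at the same place.

Because the earlier step is no change at the digits printed from compound 1 to compound 2 (within the scatter), the step expected from compound 3 to compound 4 is a 1.0-fold higher number from compound 3 to compound 4 (0.02 log units; within the scatter). Compound 4 is estimated at 250 nM, expected between 120 nM and 520 nM.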

Compound 4, half-maximal inhibitory concentration: 160 nM
Compound 4: the middle estimate sits 1.6-fold (0.19 log units) above what was measured; measured number inside the range.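

In this assay the 1,3-thiazol-2-yl group on the sulfonamide nitrogen gives a 1.5-fold lower number from compound 3 to compound 4 (0.18 log units; within the scatter) and the two cores can be set side by side: the same change on two cores in this assay, no change at the digits printed (within the scatter) from compound 1 to compound 2 and a 1.5-fold lower number (0.18 log units; within the scatter) from compound 3 to compound 4, 1.5-fold (0.18 log units) apart, within the scatter of two such steps.
In these two pairs, the change carries from one core to the other with neither step nor gap beyond the scatter. This does not show that the group raises or lowers the number on either core, and two pairs say nothing about a third core.

Still open, going by these compounds, is whether another group on the sulfonamide nitrogen, such as pyridin-2-yl or methyl, would give a step beyond the scatter. Also open, on these data alone, is how the same change behaves on a core carrying an amine in place of the chlorine.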